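This account rests on a few compounds, and the source may have more. Where it says the series, first, only, none or still open, it means among the compounds named here.

Compound 1 `CCCCCCC(CCCCCC)c1cccc(N2CCNCC2)n1` gives > 300 mg/kg
Compound 2 `CCCCSc1cccc(N2CCNCC2)n1` gives 100 mg/kg
Compound 3 `c1cc(CC2CCCCC2)nc(N2CCNCC2)c1` gives 100 mg/kg

These three compounds share one core and differ only in the group attached to it. In a functional assay on the whole organism with Mus musculus as the target, in the maximal electroshock model, with a stated time of 120 min (on this read-out higher numbers stand for an effect only at larger amounts of compound and lower numbers for an effect already at smaller amounts), compound 3 gives 100 mg/kg, level with compound 2 at the digits shown, so the two cannot be told apart within the usual scatter. Compound 1 reached only a limit of the measurement, (the limit of > 300 mg/kg in this assay, at which 1 of the 3 values shown sits), and so gives no number. Compound 4 `CCCCCCc1cccc(N2CCNCC2)n1` is not yet measured. Its difference from compound 3 is pentyl in place of cyclohexyl on a saturated chain carbon bound to an aromatic carbon. Among the compounds with values here, no measured pair shows such a step, so its size cannot be read from the data. An estimated step of a 1.5-fold higher number from compound 3 to compound 4 (0.18 log units; within the scatter) is expected. Compound 4 is therefore expected to give 150 mg/kg in this assay, within 60 mg/kg to 300 mg/kg.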

Compound 4, minimum effective dose: 10 mg/kg
Compound 4: middle estimate off by 15-fold (1.18 log units), on the high side; the whole stated range lies above it.
By their numbers in this assay, from the lowest: compound 4; then compounds 2 and 3 (each within the scatter of the next). At a limit, above all of these: compound 1.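

Pentyl in place of cyclohexyl on a saturated chain carbon bound to an aromatic carbon gives a 10-fold lower number from compound 3 to compound 4 (1.00 log units; beyond the scatter), so the effect appears at smaller amounts once the ring is gone. Hexyl in place of butylsulfanyl on an aromatic carbon gives a 10-fold lower number from compound 2 to compound 4 (1.00 log units; beyond the scatter), so the group here clearly matters, which compound 2 and compound 3 alone, being level, did not reveal. Nothing measured here explains either step. From the compounds shown here alone, it stays open whether a longer chain, or an amine or a carboxylic acid in place of hexyl, would do the same.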